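The compounds below may be only part of what the source reports. "The series", "measured", "known", "first", "only" and "open" are said of these compounds alone.

In an assay on isolated protein for inhibition of tyrosine-protein kinase receptor UFO (Homo sapiens), read by LC-MS (a higher number here means a weaker inhibitor, a lower number a stronger inhibitor), the three compounds measured so far are:

Compound 1 `CN(Cc1ccc2nccn2c1)c1nnc(-c2ccc(-c3ccccc3)cc2)o1` gives 3160 nM.
Compound 2 `CN(Cc1ccc2nccn2c1)c1nnc(-c2ccc(-c3ccccc3F)cc2)o1` gives 1580 nM.
Compound 3 `COc1ccccc1-c1ccc(-c2nnc(N(C)Cc3ccc4nccn4c3)o2)cc1` gives 1580 nM.

Compound 3 stands level with compound 2 at the digits shown, and the two together sit at the lower end of the three numbers; the gap to compound 1, a 2.0-fold lower number from compound 1 to compound 3 (0.30 log units; within the scatter), lies within the scatter. Compound 4 `CN(Cc1ccc2nccn2c1)c1nnc(-c2ccc(-c3ccccc3C#N)cc2)o1` differs from compound 3 by cyano in place of methoxy on an aromatic carbon. Within the data shown here, the steps that bear on this swap at the same position are a 2.0-fold lower number from compound 1 to compound 2 (0.30 log units; within the scatter), a 2.0-fold lower number from compound 1 to compound 3 (0.30 log units; within the scatter) and no change at the digits printed from compound 2 to compound 3 (within the scatter), none of them beyond the scatter. In this assay compound 4 is therefore expected to show no step beyond the scatter, a 1.1-fold higher number from compound 3 to compound 4 (0.06 log units; within the scatter). The estimate for compound 4 is 1800 nM, with a range from 700 nM to 4500 nM.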

Compound 4, half-maximal inhibitory concentration: 3980 nM
Compound 4: the middle estimate sits 2.2-fold (0.34 log units) below what was measured, and the stated range covers the measured number.
By their numbers in this assay, from the lowest: compounds 2, 3, 1 and 4 (each within the scatter of the next, the first and the last beyond it).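

At this position, on an aromatic carbon ortho to a large group, cyano is the only group shown that opens a step beyond the scatter, with a 2.5-fold higher number from compound 3 to compound 4 (0.40 log units; beyond the scatter) in this assay and a 2.5-fold higher number from compound 2 to compound 4 (0.40 log units; beyond the scatter) on the same modest scale. Set against hydrogen, however, cyano gives a 1.3-fold higher number from compound 1 to compound 4 (0.10 log units; within the scatter) and stays within the scatter, so the change separates it from methoxy and fluoro but not from hydrogen. Nothing measured here bears on the origin of this difference.

The compounds shown leave open whether any group at this position moves the number beyond the scatter from that of compound 1. An amine, a carboxylic acid or a longer chain could test this.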